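This account rests on a few compounds, and the source may have more. Where it says the series, first, only, none or still open, it means among the compounds named here.

Measured compounds in a functional assay on SMMC-7721 cells (Homo sapiens) for antiproliferative activity, read by MTT assay, with a stated time of 48 h; on this read-out higher numbers stand for weaker inhibition and lower numbers for stronger inhibition:
- compound 1, `COc1cccc(C(=O)c2ccc(OC)c(OC(=O)CCC(=O)OC[C@@H]3C=C[C@H](n4cc(C)c(=O)[nH]c4=O)O3)c2)c1`: 820 nM
- compound 2, `COc1cc(OC)c(C(=O)c2ccc(OC)c(OC(=O)CCC(=O)OC[C@@H]3C=C[C@H](n4cc(C)c(=O)[nH]c4=O)O3)c2)cc1OC`: 2860 nM
- compound 3, `COc1ccc(C(=O)c2ccc(F)cc2)cc1OC(=O)CCC(=O)OC[C@@H]1C=C[C@H](n2cc(C)c(=O)[nH]c2=O)O1`: not yet measured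

For the measured compounds named here, of the two measured compounds, compound 2 gives the highest number in this assay; its only neighbour is compound 1, and the single measured step, a 3.5-fold higher number from compound 1 to compound 2 (0.54 log units; beyond the scatter), separates them. Compound 3 differs from compound 2 in one place: 4-fluorophenyl in place of 2,4,5-trimethoxyphenyl on a carbonyl carbon. Going by the values given here, no measured step introduces 4-fluorophenyl on the carbonyl carbon, so the only guide is a 3.5-fold higher number from compound 1 to compound 2 (0.54 log units; beyond the scatter), which shows that the compound carrying the group with fewer heavy atoms on that carbon gave the lower number. Since 4-fluorophenyl is again the smaller group, a modest drop in the number is expected, by about a 2.4-fold lower number from compound 2 to compound 3 (0.38 log units; beyond the scatter). Compound 3 is therefore estimated at 1200 nM in this assay, with a range from 400 nM to 4000 nM.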

Compound 3, half-maximal inhibitory concentration: 22600 nM
The estimate for compound 3 lay 19-fold (1.27 log units) below the measured number, and the stated range ends below it.
By their numbers in this assay, from the lowest: compound 1; then compound 2; then compound 3.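

In this assay, the smaller group on the carbonyl carbon no longer gives the lower number: a 7.9-fold higher number from compound 2 to compound 3 (0.90 log units; beyond the scatter), and a 28-fold higher number from compound 1 to compound 3 (1.44 log units; beyond the scatter). Compound 3 therefore goes against the pattern suggested by the first two compounds, and the numbers do not follow group size, since compound 2, with 2,4,5-trimethoxyphenyl, the largest group, falls in the middle. Of the three, compound 3 alone has no methoxy group on this ring, and it shows the weakest inhibition, so this position responds to more than the number of heavy atoms.

As far as these compounds go, how a plain phenyl ring, or a ring bearing an amine or a carboxylic acid, would behave on this carbonyl carbon remains open. Nothing available here explains why these groups differ so widely.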